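Sulfamoyl for carbamoyl on the piperidine nitrogen

This account rests on a few compounds, and the source may have more. Where it says the series, first, only, none or still open, it means among the compounds named here.

Measured so far:
compound 1 `O=C(/C(=N/O)Nc1ccc(F)c(Br)c1)C1CCN(S(=O)(=O)NCc2ccccc2)CC1`: 262 nM
compound 2 `O=C(/C(=N/O)Nc1ccc(F)c(Br)c1)C1CCN(C(=O)NCc2ccccc2)CC1`: 28 nM
compound 3 `O=C(Nc1ccccc1)[C@H]1CC[C@H](C(=O)/C(=N/O)Nc2ccc(F)c(Br)c2)CC1`: 197 nM

In an assay on tissue (HeLa cells) for inhibition of Indoleamine 2,3-dioxygenase 1 (Homo sapiens), with a stated time of 48 h (on this read-out higher numbers stand for weaker inhibition and lower numbers for stronger inhibition), compound 2 gives the lowest number of the three; compound 3 sits a step above it that is beyond the scatter, and compound 1 sits furthest above, also beyond the scatter. Among the compounds with values here, the two values of compound 1 and compound 2 show that the sulfamoyl-bearing member of this pair is the weaker one, though the two differ in more than one place and no single step between them is established.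

The unmeasured compound 4 `O=C(/C(=N/O)Nc1ccc(F)c(Br)c1)C1CCN(S(=O)(=O)Nc2ccccc2)CC1` is reached from compound 2 by the change (phenylsulfamoyl in place of benzylcarbamoyl on an amine nitrogen in a ring).

Within the data shown here, no measured step covers this change alone. Given that compound 1 gives 262 nM with a related sulfamoyl group and compound 3 gives 197 nM with a phenyl amide, the expectation is that compound 4 lands above compound 2, by a step that is expected to be beyond the scatter and in the direction of weaker inhibition, a 5.4-fold higher number from compound 2 to compound 4 (0.73 log units; beyond the scatter). Compound 4 is estimated at 150 nM, within a range from 50 nM to 500 nM.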

Compound 4, half-maximal inhibitory concentration: 150 nM
The estimate for compound 4 equals the measured number at the digits printed; the measured number falls inside the stated range.
By their numbers in this assay, from the lowest: compound 2; then compounds 4, 3 and 1 (each within the scatter of the next).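

In this assay, phenylsulfamoyl in place of benzylcarbamoyl on the amine nitrogen in the ring gives a 5.4-fold higher number from compound 2 to compound 4 (0.73 log units; beyond the scatter) as a single-place change at this position, and the step lies beyond the scatter. Phenyl in place of benzyl on a sulfonamide nitrogen gives a 1.7-fold lower number from compound 1 to compound 4 (0.24 log units; within the scatter) and so does not separate the two sulfamoyl compounds on this read-out. Compound 4 therefore groups with compound 1 rather than with compound 2, which stands at 28 nM in this series.

The step from compound 2 to compound 4 changes both the group on the ring nitrogen and the aryl arm, so the two contributions cannot be told apart here; a phenylcarbamoyl group on this nitrogen would divide that change into its two parts. Also open, as far as these compounds go, is how far the position tolerates other groups, such as a phenethyl chain on the sulfamoyl nitrogen or a plain methylsulfonyl group on the ring nitrogen. Nothing in hand explains why the numbers fall as they do.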